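The compounds below may be only part of what the source reports. "The series", "measured", "known", "first", "only" and "open" are said of these compounds alone.

Among the compounds with values here, compound 1 `CC1(C)[C@H]2CC[C@]1(C)N(Cc1cn(-c3ccccc3O)nn1)C(=O)C2` stands at the top of the three numbers measured so far: in a functional assay on LoVo cells (Homo sapiens) for inhibition, read by MTT assay, with a stated time of 24 h (a higher number here means a weaker inhibitor, a lower number a stronger inhibitor), compound 1 gives 540 nM. Compound 2 `CC1(C)[C@H]2CC[C@]1(C)N(Cc1cn(-c3ccc(F)cc3)nn1)C(=O)C2` gives 40 nM in this assay, and compound 3 `COc1cccc(-n2cc(CN3C(=O)C[C@@H]4CC[C@@]3(C)C4(C)C)nn2)c1` gives 80 nM. Both departures from compound 1 lower the number well beyond the scatter, a 14-fold lower number from compound 1 to compound 2 (1.13 log units; beyond the scatter) and a 6.8-fold lower number from compound 1 to compound 3 (0.83 log units; beyond the scatter), while a 2.0-fold higher number from compound 2 to compound 3 (0.30 log units; within the scatter) lies within the scatter. Compound 4 `CC1(C)[C@H]2CC[C@]1(C)N(Cc1cn(-c3ccccc3F)nn1)C(=O)C2` keeps the shared core and differs from compound 1 only at the ring on the aromatic nitrogen: fluoro in place of hydroxy on an aromatic carbon. The hydroxy leaves and a fluoro enters, so that the 2-hydroxyphenyl becomes a 2-fluorophenyl. Within the data shown here, no measured step tests this exact exchange. The closest guide is compound 2, where a 4-fluorophenyl stood in place of the 2-hydroxyphenyl, and the step from compound 1 to compound 3 points the same way. Since every measured change away from the 2-hydroxyphenyl lowers the number beyond the scatter, a lower number is expected for compound 4 too, though with less confidence than a repeat of the measured steps would give. Compound 4 is therefore estimated at 90 nM, within 30 nM to 300 nM, an expected step of a 6.0-fold lower number from compound 1 to compound 4 (0.78 log units; beyond the scatter).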

Compound 4, half-maximal inhibitory concentration: 40 nM
Compound 4: the middle estimate sits 2.3-fold (0.35 log units) above what was measured; measured number inside the range.
By their numbers in this assay, from the lowest: compounds 2, 4 and 3 (each within the scatter of the next); then compound 1.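

Within the data shown here, the exchange at this position is now tested directly: with the ring and its place on it kept, a 14-fold lower number from compound 1 to compound 4 (1.13 log units; beyond the scatter) in this assay, so fluoro in place of hydroxy on an aromatic carbon ortho to a large group is enough for a large step, and the earlier steps, which changed the placement of the group as well, could not show this. Moving the fluoro shows no separate effect, with no change at the digits printed from compound 2 to compound 4 (within the scatter), and the 3-methoxyphenyl is no further apart, with a 2.0-fold lower number from compound 3 to compound 4 (0.30 log units; within the scatter), so compounds 2, 3 and 4 cannot be told apart here and compound 1 alone stands away from them. Nothing given here explains why the hydroxy compound stands apart from the other three.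

The compounds shown leave open whether the 2-hydroxyphenyl stands apart through the hydroxy itself at this place, or whether an amine or a methoxy on the same aromatic carbon would give a number like that of compound 1 or like that of compound 4. They also leave open how an unsubstituted phenyl, or a carboxylic acid on the ring, would compare with these four compounds.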